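Predicting metabolic stability for compound 4 from compound 1

The source may report more compounds than this note shows. Statements on the series, on what has been measured and on what is new or still open speak of the compounds shown alone.

Compound 1 `COc1cc([C@](O)(CCN(C)C)[C@@H](c2cc3cc(Br)ccc3nc2OC)c2cccc(OC)c2F)cc(OC(F)F)n1` gives 6.4 uL/min in an ADME assay on microsomes from liver (Mus musculus) for metabolic stability; a lower number here means slower removal, a higher number faster removal of the compound.
Compound 2 `COc1cc([C@](O)(CCN(C)C)[C@@H](c2cc3cc(Br)ccc3nc2OC)c2ccnc(OC)c2OC)cc(OC(F)F)n1` gives 4.9 uL/min in this assay.
Compound 3 `COc1cc([C@](O)(CCN(C)C)[C@@H](c2cc3cc(C#N)ccc3nc2OC)c2ccnc(OC)c2OC)cc(N(C)C)n1` gives 16 uL/min in this assay.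

Compound 1 holds the second highest of the three numbers. Its nearest neighbour is compound 2, and the step of a 1.3-fold lower number from compound 1 to compound 2 (0.12 log units; within the scatter) lies within the scatter, so the two cannot be ordered. For the measured compounds named here, compound 3 stands furthest away, with a number clearly higher than that of compound 1; compound 3 differs from compound 2 in two places, so no single step is drawn between them.

Compound 4 `CCSc1cc([C@](O)(CCN(C)C)[C@@H](c2cc3cc(Br)ccc3nc2OC)c2cccc(OC)c2F)cc(SCC)n1` differs from compound 1 by a group of 12 heavy atoms (9 carbon, 1 nitrogen, 2 sulfur; one six-membered aromatic ring with 1 hetero atom) in place of a group of 12 heavy atoms (7 carbon, 1 nitrogen, 2 oxygen, 2 fluorine; one six-membered aromatic ring with 1 hetero atom), on a saturated chain carbon bound to an oxygen on a saturated carbon and two saturated chain carbons. Going by the values given here, no measured step touches this position: the one measured step changes a different group and was within the scatter. The expectation for compound 4 therefore rests on the spread of the three measured numbers rather than on a direct precedent, and the expected step of a 1.9-fold higher number from compound 1 to compound 4 (0.27 log units; within the scatter) carries wide uncertainty. Compound 4 is estimated at 12 uL/min, within a range from 5 uL/min to 30 uL/min.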

Compound 4, intrinsic clearance in a liver preparation (reported as CLH), per the amount of preparation that the assay uses: 12 uL/min
Estimate against measurement, compound 4: no gap at the digits printed, within the range that was stated.
By their numbers in this assay, from the lowest: compounds 2, 1, 4 and 3 (each within the scatter of the next, the first and the last beyond it).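

This position now has a measured step of its own in this assay: a group of 12 heavy atoms with 9 carbon, 1 nitrogen and 2 sulfur replaces one with 7 carbon, 1 nitrogen, 2 oxygen and 2 fluorine, giving a 1.9-fold higher number from compound 1 to compound 4 (0.27 log units; within the scatter). Even this change of the whole group, with its oxygen and fluorine atoms gone and sulfur atoms in their place, leaves the two compounds indistinguishable in this read-out, so the position tolerates this exchange without a clear shift in the number. Nothing shown here bears on what lies behind this result.

From the compounds shown here alone, both ring substituents differ at once, so the share of each in the step stays unknown. Going by these compounds, how a longer chain on the sulfur atoms or a primary amine on this ring would read also remains open.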